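The source may hold more compounds than are shown below. What is called first, only, known or untested is meant among the compounds shown, and "the series" means these compounds.

Measured so far in a functional assay on HCC827 cells (Homo sapiens) for antiproliferative activity, read by MTT assay, with a stated time of 72 h; a lower number here means a stronger inhibitor, a higher number a weaker inhibitor:
compound 1 `CN1CCN(c2ccc(Nc3ncc4nc(Nc5ccc(F)cc5)n([C@H]5CCCNC5)c4n3)cc2)CC1`: 38 nM
compound 2 `CC(=O)N1CC[C@H](n2c(Nc3ccccc3)nc3cnc(Nc4ccc(N5CCN(C)CC5)cc4)nc32)C1`: 260 nM
compound 3 `CN1CCN(c2ccc(Nc3ncc4nc(Nc5ccccc5)n([C@@H]5CCN(C(=O)OC(C)(C)C)C5)c4n3)cc2)CC1`: 12 nM

Compound 1 stands second of the three: compound 3 sits beyond the scatter with the lower number, compound 2 beyond the scatter with the higher one.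

Compound 4 `CCOC(=O)CN1CC[C@H](n2c(Nc3ccc(F)cc3)nc3cnc(Nc4ccc(N5CCN(C)CC5)cc4)nc32)C1` is the next member to be tested. It departs from compound 1 as follows: 1-((ethoxycarbonyl)methyl)pyrrolidin-3-yl in place of piperidin-3-yl on an aromatic nitrogen

Among the measured compounds shown here, the single measured step, a 22-fold lower number from compound 2 to compound 3 (1.34 log units; beyond the scatter), concerns two compounds that both carry a pyrrolidin-3-yl ring; it shows that what sits on the pyrrolidine nitrogen can move this assay strongly, yet it covers neither the change of ring nor the (ethoxycarbonyl)methyl group. Compound 1, with a ring bearing a hydrogen-bond donor, and compound 3, with none, both lie low. For the measured compounds named here, no measured pair isolates the change from compound 1 to compound 4, so the direction remains open; the step is expected to be modest, a 1.1-fold higher number from compound 1 to compound 4 (0.02 log units; within the scatter), within or just beyond the scatter. The estimate for compound 4 is therefore 40 nM, with a range from 12 nM to 130 nM.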

Compound 4, half-maximal inhibitory concentration: 1810 nM
Beside the measured number, compound 4's estimate is 45-fold (1.66 log units) below it; the measured number lies above the stated range.
By their numbers in this assay, from the lowest: compound 3; then compound 1; then compound 2; then compound 4.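

In this assay, the position on the aromatic nitrogen proved sensitive to a combined change of ring and substituent: 1-((ethoxycarbonyl)methyl)pyrrolidin-3-yl in place of piperidin-3-yl gives a 48-fold higher number from compound 1 to compound 4 (1.68 log units; beyond the scatter) and places compound 4 at the high end of the series. Earlier compounds showed a large step only between two groups on a pyrrolidine nitrogen, whereas this change swaps a six-membered ring for a five-membered one, removes the hydrogen-bond donor and adds the (ethoxycarbonyl)methyl group at once. No information at hand explains the size of this step.

The change of ring and the (ethoxycarbonyl)methyl group enter together in compound 4. The measured compounds do not separate them. An unsubstituted pyrrolidin-3-yl or a 1-(carboxymethyl)pyrrolidin-3-yl, bearing a carboxylic acid in place of the ethyl ester, on the core of compound 1 would help separate these two changes.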